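Swapping chloro for fluoro on a weak collagen promoter inhibitor

This account rests on a few compounds, and the source may have more. Where it says the series, first, only, none or still open, it means among the compounds named here.

Four compounds sharing one core were compared in an assay on LX2 cells for inhibition of COL1A1 promoter (Homo sapiens), read by a luciferase reporter, with a stated time of 24 h, tested at 50 uM; a higher number here means a stronger effect of the compound at the concentration tested, a lower number a weaker effect. Compound 1, `CN(C)c1ccc2c(=O)c(C(=O)Nc3cc(F)cc(F)c3)cn(-c3ccc(OCCCCCCC[N+]45CCN(CC4)CC5)cc3Cl)c2n1`, gives 80% in this assay. Compound 2, `CN(C)c1ccc2c(=O)c(C(=O)Nc3cc(F)cc(F)c3)cn(-c3ccc(OCCCCCCC[N+]45CCN(CC4)CC5)cc3F)c2n1`, differs from it only by fluoro in place of chloro on an aromatic carbon, and compound 2 gives 42.4%. That change made a step of a number 37.6 percentage points lower from compound 1 to compound 2 (beyond the scatter), so the chloro partner is the clearly stronger of the two.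

Compound 3, `CN(C)c1ccc2c(=O)c(C(=O)Nc3cc(F)cc(F)c3)cn(-c3ccc(OCCCCCCC[N+](C)(C)C4CCCCC4)cc3Cl)c2n1`, keeps the chloro but carries a different charged end on the chain: a group of 9 heavy atoms (8 carbon, 1 nitrogen; one six-membered non-aromatic ring of carbon only) in place of a group of 8 heavy atoms (6 carbon, 2 nitrogen; 2 six-membered non-aromatic rings with 2 hetero atoms each), on a saturated chain carbon, seven bonds along the chain from an oxygen on an aromatic ring. In this assay compound 3 came back as "not active" (no number reported), with no single number reported.

Compound 4, `CN(C)c1ccc2c(=O)c(C(=O)Nc3cc(F)cc(F)c3)cn(-c3ccc(OCCCCCCC[N+](C)(C)C4CCCCC4)cc3F)c2n1`, stands to compound 3 as compound 2 stands to compound 1, through (fluoro in place of chloro on an aromatic carbon). The surroundings of the change are the same in both pairs, so this is the same change on a different chain end.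

Two facts guide the expectation for compound 4. First, compound 3 itself gave no measurable effect, "not active" (no number reported). Second, the only measured instance of this change lowered the read-out sharply because of a number 37.6 percentage points lower from compound 1 to compound 2 (beyond the scatter). Starting from a compound with no reported activity and applying a change that weakened compound 1, little effect is expected for compound 4, and a good chance remains that it too is reported only as inactive. Compound 4 is estimated to give 5%, expected to fall between 0% and 25%.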

Compound 4, a percentage reported as inhibition, at one concentration (the size of the read-out at that concentration, not a potency): "not active" (no number reported)
Compound 4 has no reported number here; there is nothing to compare the estimate with.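

In this assay compound 3 gives "not active" (no number reported) and compound 4 gives "not active" (no number reported), so no step can be read for this swap of chloro for fluoro. No measurement shown here offers an explanation for this result. The compounds shown leave open whether fluoro in place of chloro changes the read-out at all on this chain end, as it did between compound 1 and compound 2.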